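Aryl sulfonyl swap: from trimethylphenyl to nitrophenyl

A few compounds are considered here, and "the series" means these few. Any claim that something is new, unique, unknown or untested is made for them only; others in the source may bear on it.

Compound 1 `COC(=O)c1ccc(C2SCC(=O)N2c2ccc(N3CCN(S(=O)(=O)c4ccc(F)cc4)CC3)cn2)c(OC)c1`: > 100000 nM
Compound 2 `COC(=O)c1ccc(C2SCC(=O)N2c2ccc(N3CCN(S(=O)(=O)c4ccc(OC)cc4)CC3)cn2)c(OC)c1`: 29400 nM
Compound 3 `COC(=O)c1ccc(C2SCC(=O)N2c2ccc(N3CCN(S(=O)(=O)c4c(C)cc(C)cc4C)CC3)cn2)c(OC)c1`: > 100000 nM

Three compounds share a core and differ only in the aryl group on the sulfonyl sulfur. In a functional assay on NALM-6 cells (Homo sapiens) for antiproliferative activity, read by MTT assay and trypan blue exclusion, with a stated time of 72 h (a higher number here means a weaker inhibitor, a lower number a stronger inhibitor), compound 1 gives > 100000 nM, which is a limit of the assay and not a number. Compound 3 also sits at a limit, > 100000 nM. Among the measured compounds shown here, compound 2 is the only one with a read number, 29400 nM. Two of the three values therefore rest at the same ceiling (the limit of > 100000 nM in this assay, at which 2 of the 3 values shown sit), which leaves compound 3 placed only as weaker than compound 2: an at least 3.4-fold higher number from compound 2 to compound 3 (0.53 log units; beyond the scatter). The step that the two limits leave unreadable from compound 1 to compound 3 cannot be sized at all, and an at least 3.4-fold lower number from compound 1 to compound 2 (0.53 log units; beyond the scatter) shows that the para substituent on the aryl ring can move the number by a readable amount.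

Compound 4 `COC(=O)c1ccc(C2SCC(=O)N2c2ccc(N3CCN(S(=O)(=O)c4ccc([N+](=O)[O-])cc4)CC3)cn2)c(OC)c1` is not yet measured. It differs from compound 3 by 4-nitrophenyl in place of 2,4,6-trimethylphenyl on a sulfonyl sulfur. The return to a singly para-substituted aryl ring puts compound 4 between the two measured para cases, compound 1 at a limit and compound 2 with a number, so the expected step of an at least 1.6-fold lower number from compound 3 to compound 4 (0.22 log units; that floor lies within the scatter) is downward but uncertain in size. Compound 4 is estimated at 60000 nM in this assay, with a range from 15000 nM to 200000 nM.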

Compound 4, half-maximal inhibitory concentration: > 100000 nM
Compound 4 was reported as a limit; the forecaster's own chance of this, stated with the estimate: 50%; at least 1.6-fold (0.22 log units) between middle value and limit.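

In this assay compound 4 gives > 100000 nM, which is a limit of the assay and not a number. Among the compounds shown here, the one readable step is an at least 3.4-fold higher number from compound 2 to compound 4 (0.53 log units; beyond the scatter), so 4-methoxyphenyl stays the only aryl group on the sulfonyl sulfur in this set with a read number, and the exchange of methoxy for nitro on the same aromatic carbon loses that number just as the exchange for fluoro does. The steps to the other two compounds cannot be read, and the ceiling now covers most of the series: the limit of > 100000 nM in this assay, at which 3 of the 4 values shown sit.

Going by these compounds, whether 4-nitrophenyl, 4-fluorophenyl and 2,4,6-trimethylphenyl differ from one another stays open, since this assay separates them only from 4-methoxyphenyl. Also open, on these data alone, is whether the read number of compound 2 belongs to methoxy alone or would carry over to an ethoxy or a dimethylamino group on that aromatic carbon, which would show whether this position can give values well clear of the ceiling.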